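Toxicity of a carbamoyl replacement on the amine nitrogen

The source may hold more compounds than are shown below. What is called first, only, known or untested is meant among the compounds shown, and "the series" means these compounds.

Measured compounds:
- compound 1 `Cc1cn([C@@H]2O[C@H](CO[Si](C)(C)C(C)(C)C)[C@@]3(OS(=O)(=O)C=C3NCC(=O)O)[C@H]2O[Si](C)(C)C(C)(C)C)c(=O)n(C)c1=O`: 300000 nM
- compound 2 `Cc1cn([C@@H]2O[C@H](CO[Si](C)(C)C(C)(C)C)[C@@]3(OS(=O)(=O)C=C3NCC(=O)C(=O)N3CCC3)[C@H]2O[Si](C)(C)C(C)(C)C)c(=O)n(C)c1=O`: 65000 nM
- compound 3 `CCOC(=O)CNC(=O)NC1=CS(=O)(=O)O[C@@]12[C@@H](CO[Si](C)(C)C(C)(C)C)O[C@@H](n1cc(C)c(=O)n(C)c1=O)[C@@H]2O[Si](C)(C)C(C)(C)C`: 16000 nM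

In a functional assay on HEL cells (Homo sapiens) for cytotoxicity, read by microscopy (on this read-out higher numbers stand for lower toxicity in this test and lower numbers for higher toxicity in this test), compound 1 gives the highest number of the three, which here means the lowest toxicity. Its nearest neighbour is compound 2, with a 4.6-fold lower number from compound 1 to compound 2 (0.66 log units; beyond the scatter); furthest is compound 3, with a 19-fold lower number from compound 1 to compound 3 (1.27 log units; beyond the scatter). Between compound 2 and compound 3 the change is a 4.1-fold lower number from compound 2 to compound 3 (0.61 log units; beyond the scatter).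

Compound 4 `CCNC(=O)NC1=CS(=O)(=O)O[C@@]12[C@@H](CO[Si](C)(C)C(C)(C)C)O[C@@H](n1cc(C)c(=O)n(C)c1=O)[C@@H]2O[Si](C)(C)C(C)(C)C` has not yet been measured. It differs from compound 1 in one place: ethylcarbamoyl in place of carboxymethyl on an amine nitrogen.

Within the data shown here, the measured step that bears most on this is the one from compound 1 to compound 3, where a carbamoyl group likewise replaced the carboxymethyl on the amine nitrogen and the number fell by a large margin, a 19-fold lower number from compound 1 to compound 3 (1.27 log units; beyond the scatter). Compound 4 carries a smaller carbamoyl group, ethylcarbamoyl, so a step in the same direction is expected, though perhaps not quite as large: the estimated step is a 12-fold lower number from compound 1 to compound 4 (1.08 log units; beyond the scatter). Compound 4 is therefore expected to give about 25000 nM, with a plausible range from 6000 nM to 100000 nM in this assay.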

Compound 4, minimum cytotoxic concentration: >= 3200 nM
Compound 4 ended at the assay's limit (the forecaster's own chance of this, stated with the estimate: 5%); the middle value is on the limit's open side.
By their numbers in this assay, from the lowest: compound 3; then compound 2; then compound 1.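

Compound 4 gives >= 3200 nM, which is a limit of the assay and not a number. Its steps from compound 1, compound 2 and compound 3 cannot be read. The compounds shown leave open how toxic compound 4 is relative to these three.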